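This account rests on a few compounds, and the source may have more. Where it says the series, first, only, none or still open, it means among the compounds named here.

Three compounds share one core and differ only in the group on the amide-type nitrogen. Compound 1 `O=C(Nc1ccc(O)cc1)c1c(NO)cc(-c2ccccc2)oc1=O` carries 4-hydroxyphenyl there. In an ADME assay on Huh-7 cells (Homo sapiens) for cytotoxicity, read by a luciferase reporter and WST assay, with a stated time of 3 days (on this read-out higher numbers stand for lower toxicity in this test and lower numbers for higher toxicity in this test), compound 1 gives only a limit, > 20000 nM. Compound 2 `Cc1cccc(NC(=O)c2c(NO)cc(-c3ccccc3)oc2=O)c1` carries 3-methylphenyl. In this assay compound 2 also stops at a limit, > 20000 nM. Compound 3 `CC(C)NC(=O)c1c(NO)cc(-c2ccccc2)oc1=O` carries isopropyl. In this assay compound 3 again reaches only a limit, > 20000 nM. The steps a step that the two limits leave unreadable from compound 1 to compound 2, a step that the two limits leave unreadable from compound 1 to compound 3 and a step that the two limits leave unreadable from compound 2 to compound 3 cannot be sized, since (the limit of > 20000 nM in this assay, at which 3 of the 3 values shown sit). Compound 4 `O=C(NCCO)c1c(NO)cc(-c2ccccc2)oc1=O` differs from compound 3 by 2-hydroxyethyl in place of isopropyl on an amide-type nitrogen. With every measured step unreadable, the expected step that the limit leaves unreadable from compound 3 to compound 4 is none beyond the scatter. Compound 4 is therefore estimated at 30000 nM, within 15000 nM to 80000 nM.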

Compound 4, half-maximal cytotoxic concentration: > 20000 nM
Compound 4 gave a limit, no number; the forecaster's own chance of this, stated with the estimate: 85%; the middle value lies beyond the limit too.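

The steps from compound 1, compound 2 and compound 3 to compound 4 cannot be read, because all four compounds stop at a limit: the limit of > 20000 nM in this assay, at which 4 of the 4 values shown sit. The compounds shown leave open whether these four groups on the amide-type nitrogen differ in toxicity at all.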